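The source may hold more compounds than are shown below. What is called first, only, known or untested is meant among the compounds shown, and "the series" means these compounds.

Compound 1 `Cc1ncnc2c1c(-c1ccoc1)cn2[C@@H]1O[C@H](CO)[C@@H](O)[C@H]1O` carries a furan-3-yl group. In a functional assay on HL-60 cells (Homo sapiens) for antiproliferative activity, read by XTT assay, with a stated time of 72 h (on this read-out lower numbers stand for stronger inhibition and higher numbers for weaker inhibition), compound 1 gives > 15000 nM, which is a limit of the assay and not a number. Compound 2 `Cc1ncnc2c1c(-c1cccs1)cn2[C@@H]1O[C@H](CO)[C@@H](O)[C@H]1O` differs from compound 1 by thiophen-2-yl in place of furan-3-yl on an aromatic carbon; in this assay compound 2 gives 5730 nM, a step of an at least 2.6-fold lower number from compound 1 to compound 2 (0.41 log units; beyond the scatter) whose size is known only as a floor owing to the limit of > 15000 nM in this assay, at which 1 of the 3 values shown sits. Compound 3 `CSc1ncnc2c1c(-c1ccoc1)cn2[C@@H]1O[C@H](CO)[C@@H](O)[C@H]1O` differs from compound 1 in its core by methylsulfanyl in place of methyl on an aromatic carbon; in this assay compound 3 gives 360 nM, a step of an at least 41-fold lower number from compound 1 to compound 3 (1.61 log units; beyond the scatter). Compound 4 `CSc1ncnc2c1c(-c1cccs1)cn2[C@@H]1O[C@H](CO)[C@@H](O)[C@H]1O` is not yet measured; it differs from compound 3 by thiophen-2-yl in place of furan-3-yl on an aromatic carbon, the same change as that between compound 1 and compound 2, made on the core of compound 3. Compound 4 is expected to show a step of a 3.0-fold lower number from compound 3 to compound 4 (0.48 log units; beyond the scatter), resting on an at least 2.6-fold lower number from compound 1 to compound 2 (0.41 log units; beyond the scatter), a size that is only a floor given (the limit of > 15000 nM in this assay, at which 1 of the 3 values shown sits). In this assay compound 4 is estimated at 120 nM, with a range from 40 nM to 400 nM.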

Compound 4, half-maximal inhibitory concentration: 1130 nM
For compound 4 the middle estimate is 9.4-fold (0.97 log units) below the measured one; measured number above the stated range.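

In this assay, the change from furan-3-yl to thiophen-2-yl did not carry over from one core to the other, as the new step, a 3.1-fold higher number from compound 3 to compound 4 (0.50 log units; beyond the scatter), runs opposite to the earlier one: the same change on two cores in this assay, an at least 2.6-fold lower number (0.41 log units; beyond the scatter) from compound 1 to compound 2 and a 3.1-fold higher number (0.50 log units; beyond the scatter) from compound 3 to compound 4, at least 8.2-fold (0.91 log units) apart, beyond the scatter of two such steps. The change from methyl to methylsulfanyl kept its direction, with a 5.1-fold lower number from compound 2 to compound 4 (0.71 log units; beyond the scatter), but not its size: the same change on two cores in this assay, an at least 41-fold lower number (1.61 log units; beyond the scatter) from compound 1 to compound 3 and a 5.1-fold lower number (0.71 log units; beyond the scatter) from compound 2 to compound 4, at least 8.2-fold (0.91 log units) apart, beyond the scatter of two such steps. The full size of these two gaps is not shown, as both rest on a value of compound 1 that is a limit: the limit of > 15000 nM in this assay, at which 1 of the 4 values shown sits.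

The compounds shown leave open whether furan-2-yl or thiophen-3-yl would follow the same course. They also leave open how a methoxy group or an amine in place of methylsulfanyl would behave.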